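Exchanging the triazole aryl group in a series at the limit

The compounds below may be only part of what the source reports. "The series", "measured", "known", "first", "only" and "open" are said of these compounds alone.

Three compounds share one core and differ only in the aryl group carried on the triazole nitrogen. Compound 1 `CCOc1ccc(-n2nncc2CN2C(=O)C3(C(C#N)=C(N)Oc4c3c3nc5ccccc5nc3c3ccccc43)c3ccccc32)cc1` bears 4-ethoxyphenyl there, and in a functional assay on HepG2 cells (Homo sapiens) for antiproliferative activity, read by MTT assay, with a stated time of 48 h (on this read-out lower numbers stand for stronger inhibition and higher numbers for weaker inhibition), compound 1 gives only a limit, > 50000 nM. Compound 2 `Cc1ccc(-n2nncc2CN2C(=O)C3(C(C#N)=C(N)Oc4c3c3nc5ccccc5nc3c3ccccc43)c3ccccc32)cc1Cl` bears 3-chloro-4-methylphenyl, and in this assay compound 2 also gives only a limit, > 50000 nM. The step that the two limits leave unreadable from compound 1 to compound 2 is therefore not readable in size. Compound 3 `Cc1ccccc1-n1nncc1CN1C(=O)C2(C(C#N)=C(N)Oc3c(N)cc4nc5ccccc5nc4c32)c2ccccc21` carries a 2-methylphenyl group and an additional amino group on the core, and in this assay compound 3 again gives only a limit, > 50000 nM. Compound 3 thus stands where every measured compound stands, because of the limit of > 50000 nM in this assay, at which 3 of the 3 values shown sit; no ordering among the three can be drawn.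

Compound 4 `N#CC1=C(N)Oc2c(N)cc3nc4ccccc4nc3c2C12C(=O)N(Cc1cnnn1-c1cccc(Br)c1)c1ccccc12` keeps the core of compound 3 and introduces (3-bromophenyl in place of 2-methylphenyl on an aromatic nitrogen). Going by the values given here, no measured step can be read in size, so there is nothing to show that changing the aryl group on the triazole nitrogen moves the activity out of the limit region. The step that the limit leaves unreadable from compound 3 to compound 4 is therefore expected to be none beyond the scatter, with compound 4 most likely again reported only as a limit. Compound 4 is estimated at 80000 nM in this assay, within a range from 30000 nM to 250000 nM.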

Compound 4, half-maximal inhibitory concentration: > 50000 nM
Compound 4: only a limit was reported (the forecaster's own chance of this, stated with the estimate: 80%); the middle value is on the limit's open side.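

Going by these compounds alone, compound 3 and compound 4 each give only a limit in this assay, so no step between them can be read in size: the limit of > 50000 nM in this assay, at which 4 of the 4 values shown sit. The compounds shown leave open whether any aryl group on the triazole nitrogen can bring activity in this series into a range where a number can be read.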